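Removing one methyl from the chloro-bearing ring of compound 1

The source may report more compounds than this note shows. Statements on the series, on what has been measured and on what is new or still open speak of the compounds shown alone.

Compound 1 `Cc1cc(C)[n+]([O-])c(Cl)c1-c1noc(-c2cc(O)c(O)c([N+](=O)[O-])c2)n1` gives 13.9% in a functional assay on the whole organism (liver, strain Wistar) for inhibition, with Rattus norvegicus as the target, with a stated time of 3 h, at a dose of 3 mg/kg by the oral route; on this read-out higher numbers stand for more inhibition at the one dose given (going by the name of the read-out) and lower numbers for less inhibition. Among the three compounds measured it sits far below compound 3 and in the same range as compound 2. Compound 2 `Cc1c(C)c(C)[n+]([O-])c(Cl)c1-c1noc(-c2cc(O)c(O)c([N+](=O)[O-])c2)n1` gives 7.9% in this assay; the step of a number 6 percentage points lower from compound 1 to compound 2 (within the scatter) is within the scatter, so the two values cannot be told apart. Compound 3 `O=[N+]([O-])c1cc(-c2nc(-c3ccc[n+]([O-])c3)no2)cc(O)c1O` lies furthest off, giving 77% in this assay, a gap from compound 1 that is well beyond the scatter; no single change connects it to compound 1, so only the two values can be set side by side.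

Compound 4 `Cc1ccc(-c2noc(-c3cc(O)c(O)c([N+](=O)[O-])c3)n2)c(Cl)[n+]1[O-]` differs from compound 1 by hydrogen in place of methyl on an aromatic carbon. For the measured compounds named here, the only measured step bearing on this change is the reverse one, methyl in place of hydrogen on an aromatic carbon, a number 6 percentage points lower from compound 1 to compound 2 (within the scatter), which stayed within the scatter. The change from compound 1 to compound 4 is therefore expected to move this assay by no more than the scatter, with no direction that can be called beyond it. The expected step is a number 4.1 percentage points higher from compound 1 to compound 4 (within the scatter). Compound 4 is expected to give 18%, within a range from 4% to 38%.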

Compound 4, a percentage reported as inhibition, in the whole organism at one dose (the size of the read-out at that dose, not a potency): 31.6%
Compound 4: middle estimate off by 13.6 percentage points, on the low side; low and high end bracket the measured number.
By their numbers in this assay, from the lowest: compounds 2 and 1 (each within the scatter of the next); then compound 4; then compound 3.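

Hydrogen in place of methyl on the aromatic carbon ortho to a large group and opposite the ring nitrogen gives a number 17.7 percentage points higher from compound 1 to compound 4 (beyond the scatter) in this assay, the first single change on the chloro-bearing ring here to exceed the scatter. The earlier step of a number 6 percentage points lower from compound 1 to compound 2 (within the scatter), which adds a methyl at a different aromatic carbon of that ring, did not separate the two values, so the ring's carbons do not all give the same result for a methyl change. No measurement at hand gives a reason for the new step.

Going by these compounds, at this carbon only methyl and hydrogen can be compared, so the effect of an amine, a methoxy group or a fluorine there remains open. Also open, on these data alone, is what replacing the chloro group with hydrogen, or removing the other methyl, would do to the value of compound 4.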